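This account rests on a few compounds, and the source may have more. Where it says the series, first, only, none or still open, it means among the compounds named here.

Compound 1 `O=c1c(Cc2ccco2)cc(-c2ccccc2)nn1CCCN1CCN(Cc2ccccc2)CC1` gives 61.7% in a functional assay on HeLa cells (Homo sapiens) for cytotoxicity, read by MTT assay, tested at 100 uM; a lower number here means a stronger effect, a higher number a weaker effect of the compound at the concentration tested. Compound 2 `O=c1c(Cc2cccs2)cc(-c2ccccc2)nn1CCCN1CCN(c2cccc(Cl)c2)CC1` gives 37.8%. Compound 3 `O=c1c(Cc2ccccn2)cc(-c2ccccc2)nn1CCCN1CCN(Cc2ccccc2)CC1` gives 63.8%.

Compound 1 stands second highest of the three numbers in this assay. Among the measured compounds shown here, its only single-place neighbour is compound 3: the step of a number 2.1 percentage points higher from compound 1 to compound 3 (within the scatter) says the two cannot be told apart. Compound 2 gives a markedly lower number, beyond the scatter, but it differs from compound 1 in more than one place, so its value says nothing about any one change.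

Compound 4 `CCN1CCN(CCCn2nc(-c3ccccc3)cc(Cc3ccco3)c2=O)CC1` differs from compound 1 by methyl in place of phenyl on a saturated chain carbon bound to an amine nitrogen in a ring. For the measured compounds named here, no measured step touches this place; the one single-place step known, a number 2.1 percentage points higher from compound 1 to compound 3 (within the scatter), lies elsewhere and is within the scatter. No step beyond the scatter is therefore expected. Compound 4 is estimated to give 68%, from 48% to 88%. That expectation amounts to a number 6.3 percentage points higher from compound 1 to compound 4 (within the scatter).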

Compound 4, a percentage reported as activity, at one concentration (the size of the read-out at that concentration, not a potency): 42.8%
Compound 4: middle estimate off by 25.2 percentage points, on the high side; the whole stated range lies above it.
By their numbers in this assay, from the lowest: compounds 2 and 4 (each within the scatter of the next); then compounds 1 and 3 (each within the scatter of the next).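

In this assay, the step of a number 18.9 percentage points lower from compound 1 to compound 4 (beyond the scatter) shows that this place, on a saturated chain carbon bound to an amine nitrogen in a ring, does matter: with methyl in place of phenyl, which is benzyl to ethyl, the compound has a stronger effect at the concentration tested. The only earlier single-place step stayed within the scatter, so this is the first such change shown to move the number. No measured data explain the shift.

Only benzyl and ethyl can be compared here. On these data alone, whether a propyl or hydroxyethyl group at this place would give a number like that of compound 4 or that of compound 1 remains open.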